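A few compounds are considered here, and "the series" means these few. Any claim that something is new, unique, unknown or untested is made for them only; others in the source may bear on it.

Measured compounds:
Compound 1 `CC(C)n1nc(-c2ccnc3[nH]c(C4CCN(CC(=O)N(C)C)CC4)cc23)ccc1=O` gives 2 in a physicochemical assay for lipophilicity, using the shake flask method, measured as octanol-water partition, at pH 7.4; on this read-out higher numbers stand for higher lipophilicity and lower numbers for lower lipophilicity.
Compound 2 `COc1cc(F)ccc1-c1ccnc2[nH]c(C3CCNCC3)nc12` gives 0 in this assay.
Compound 3 `Cc1nc2ccc(-c3ccnc4[nH]c(C5CCN(CC(=O)N(C)C)CC5)cc34)cc2n1C(C)C` gives 3.1 in this assay.

Among these three, compound 1 holds the second highest reading: compound 3 sits above it, beyond the scatter, and compound 2 sits below it, further away and likewise beyond the scatter. No pair of these compounds differs in a single place, so the gaps between them are taken only as they stand.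

Compound 4 `CN(C)C(=O)CN1CCC(c2cc3c(-c4ccc(=O)n(C)c4)ccnc3[nH]2)CC1` is not yet measured. It differs from compound 1 in one place: a group of 8 heavy atoms (6 carbon, 1 nitrogen, 1 oxygen; one six-membered aromatic ring with 1 hetero atom) in place of a group of 10 heavy atoms (7 carbon, 2 nitrogen, 1 oxygen; one six-membered aromatic ring with 2 hetero atoms), on an aromatic carbon

The entering group carries fewer heavy atoms and fewer acceptors than the leaving group, so a modest downward step is expected for compound 4, roughly a number 0.50 log units lower from compound 1 to compound 4 (beyond the scatter) in this assay. Compound 4 is thus estimated at 1.5, with a range from 0.8 to 2.2.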

Compound 4, distribution coefficient: 1.1
Compound 4: the middle estimate sits 0.40 log units above what was measured; low and high end bracket the measured number.
By their numbers in this assay, from the lowest: compound 2; then compound 4; then compound 1; then compound 3.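

For the compounds shown here, replacing the group of 10 heavy atoms with the group of 8 heavy atoms on this aromatic carbon, opposite the ring nitrogen, gives the first single-place step in the set: a number 0.90 log units lower from compound 1 to compound 4 (beyond the scatter) in this assay. The reading at this position therefore moves with the group it carries, which the earlier gaps, spread over several differences, could not show. Nothing available accounts for the size of this step.

From the compounds shown here alone, what a nitrile or an amine on this same carbon would give in this assay stays open. So does whether the step would recur on another core.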